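A few compounds are considered here, and "the series" means these few. Any claim that something is new, unique, unknown or untested is made for them only; others in the source may bear on it.

Working notes on the benzyloxy amide series in an assay on Sf9 cells for inhibition of Leucine-rich repeat serine/threonine-protein kinase 2 (Homo sapiens), read by TR-FRET, with stated times of 30 min and 2 h; a higher number here means a weaker inhibitor, a lower number a stronger inhibitor.

Compound 1 `CN1CC2(C1)CN(c1ccc(OCc3ccccc3)c(C(=O)Nc3ccnnc3)c1)C2` gives 25.1 nM. Among the three measured numbers it stands level with compound 3 `O=C(Nc1cccc(Cl)c1)c1cc(C(F)(F)F)ccc1OCc1ccccc1`, which gives 25.1 nM; both are the highest of the three, and compound 2 `O=C(Nc1ccnnc1)c1cc(N2CCC(CO)CC2)ccc1OCc1ccccc1`, which gives 20 nM, lies only a 1.3-fold lower number from compound 1 to compound 2 (0.10 log units; within the scatter) away, within the scatter. The three measured compounds are therefore indistinguishable in this assay.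

The next compound, compound 4 `O=C(Nc1ccnnc1)c1cc(C(F)(F)F)ccc1OCc1ccccc1`, differs from compound 1 in one place: a group of 4 heavy atoms (1 carbon, 3 fluorine; no ring) in place of a group of 8 heavy atoms (6 carbon, 2 nitrogen; 2 four-membered non-aromatic rings with 1 hetero atom each), on an aromatic carbon.

Among the measured compounds shown here, the only step measured at that same position is the one from compound 1 to compound 2, in which another group of 8 heavy atoms replaced the two four-membered rings and the number moved a 1.3-fold lower number from compound 1 to compound 2 (0.10 log units; within the scatter), within the scatter. Compound 3 already carries trifluoromethyl at the position where compound 4 will carry it, though with a different amide partner, and its value is the same as that of compound 1 at the digits printed. Neither observation gives ground for a step beyond the scatter, so no change beyond the scatter is expected from compound 1 to compound 4, i.e. a 1.0-fold lower number from compound 1 to compound 4 (0.00 log units; within the scatter). Compound 4 is thus estimated at 25 nM, with a range of 10 nM to 63 nM.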

Compound 4, half-maximal inhibitory concentration: 15.9 nM
Compound 4: middle estimate off by 1.6-fold (0.20 log units), on the high side; the measured number falls inside the stated range.
By their numbers in this assay, from the lowest: compounds 4, 2, 1 and 3 (each within the scatter of the next).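

In this assay, the aromatic carbon meta to the (pyridazin-4-yl)carbamoyl group and para to the benzyloxy group now has a small group with no ring and no hydrogen-bond acceptors, and the step to it from the group with two four-membered rings is a 1.6-fold lower number from compound 1 to compound 4 (0.20 log units; within the scatter). The step from 4-(hydroxymethyl)piperidin-1-yl is a 1.3-fold lower number from compound 2 to compound 4 (0.10 log units; within the scatter), so neither ring-bearing group can be told apart from trifluoromethyl at this position, despite the difference in size and ring content. The amide side also gets its first comparison in one place, with trifluoromethyl held fixed: pyridazin-4-yl in place of 3-chlorophenyl gives a 1.6-fold lower number from compound 3 to compound 4 (0.20 log units; within the scatter), again without separating the two compounds, and no accompanying measurement offers an explanation for these close readings.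

With all steps shown lying within the scatter, it remains open which kind of group at this position would produce a step beyond it, for example a carboxylic acid, a primary amine or a longer alkyl chain. From the compounds shown here alone, the benzyloxy group is common to all four compounds, so the effect of replacing it with a smaller group such as methoxy also remains open.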